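Swapping the amine for dimethoxy on the ketone arm

A few compounds are considered here, and "the series" means these few. Any claim that something is new, unique, unknown or untested is made for them only; others in the source may bear on it.

Measured so far:
- compound 1, `COc1ccc(-c2cc(/C=C/C(=O)c3ccc(N)cc3)[nH]n2)cc1`: 2120 nM
- compound 2, `COc1cc(-c2cc(/C=C/C(=O)c3ccc(N)cc3)[nH]n2)cc(OC)c1OC`: 2040 nM

Both compounds were tested in a functional assay on 786-0 cells (Homo sapiens) for inhibition, read by sulforhodamine B assay, with a stated time of 48 h; a higher number here means a weaker inhibitor of growth, a lower number a stronger inhibitor of growth. In this assay compound 1 gives 2120 nM and compound 2 gives 2040 nM. Compound 2 holds the lowest of the two numbers, yet its nearest neighbour, compound 1, sits so close that the two values lie within the usual scatter of repeated measurements, so neither can be called the stronger inhibitor of growth.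

Compound 3, `COc1ccc(C(=O)/C=C/c2cc(-c3cc(OC)c(OC)c(OC)c3)n[nH]2)cc1OC`, has not yet been measured. It keeps the core of compound 2 but differs in one place: 3,4-dimethoxyphenyl in place of 4-aminophenyl on a carbonyl carbon. Among the measured compounds shown here, no measured pair shows the effect of this change, so there is no step to lean on. With the two known values sitting side by side, the expectation for compound 3 is a step from compound 2 of about a 1.2-fold higher number from compound 2 to compound 3 (0.09 log units; within the scatter), that is, no change beyond the scatter, perhaps leaning toward a slightly weaker inhibitor of growth. The estimate for compound 3 in this assay is 2500 nM, with a range from 800 nM to 8000 nM.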

Compound 3, concentration for 50% growth inhibition: 1400 nM
For compound 3 the middle estimate is 1.8-fold (0.25 log units) above the measured one, within the range that was stated.
By their numbers in this assay, from the lowest: compounds 3, 2 and 1 (each within the scatter of the next).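

In this assay the swap of 4-aminophenyl for 3,4-dimethoxyphenyl on the carbonyl carbon gives the first step read at this place (a 1.5-fold lower number from compound 2 to compound 3 (0.16 log units; within the scatter)), and this step stays within the scatter, so the two compounds cannot be put in order. The groups differ clearly in what is counted, with 10 heavy atoms entering against 7 leaving and 0 hydrogen-bond donors against 1, yet no change beyond the scatter appears. On the core of compound 2, then, the 4-aminophenyl group and its amine are not needed to keep growth inhibition at this level. Nothing measured here accounts for the two groups reading alike.

On these data alone, whether a phenyl carrying a hydroxyl, a chlorine or a carboxylic acid on this carbonyl carbon would move the number beyond the scatter remains open. So does whether the same swap would read alike on the core of compound 1, and a single step at this place sets no trend.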